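This account rests on a few compounds, and the source may have more. Where it says the series, first, only, none or still open, it means among the compounds named here.

Measured compounds:
compound 1, `S=C(Nc1ccccc1)N1N=C(c2ccccc2)CC1c1ccc2c(c1)OCCO2`, gives 6630 nM in a functional assay on HT-29 cells (Homo sapiens) for antiproliferative activity, read by MTT assay, with a stated time of 48 h; a higher number here means a weaker inhibitor of growth, a lower number a stronger inhibitor of growth
compound 2, `Cc1ccc(C2=NN(C(=S)Nc3ccccc3)C(c3ccc4c(c3)OCCO4)C2)cc1`, gives 19500 nM
compound 3, `FC(F)(F)c1ccc(C2=NN(C(=S)Nc3ccccc3)C(c3ccc4c(c3)OCCO4)C2)cc1`, gives 97500 nM

Among these three, compound 2 stands second highest. Its nearest neighbour is compound 1, the step being a 2.9-fold higher number from compound 1 to compound 2 (0.47 log units; beyond the scatter); its furthest is compound 3, the step being a 5.0-fold higher number from compound 2 to compound 3 (0.70 log units; beyond the scatter). The unmeasured compound 4, `COc1ccccc1C1=NN(C(=S)Nc2ccccc2)C(c2ccc3c(c2)OCCO3)C1`, differs from compound 2 in one place: 2-methoxyphenyl in place of 4-methylphenyl on a carbon with a double bond to nitrogen.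

Going by the values given here, the steps that bear on this all alter the same aromatic ring. Going from hydrogen to methyl gave a 2.9-fold higher number from compound 1 to compound 2 (0.47 log units; beyond the scatter), from hydrogen to trifluoromethyl a 15-fold higher number from compound 1 to compound 3 (1.17 log units; beyond the scatter), and from methyl to trifluoromethyl a 5.0-fold higher number from compound 2 to compound 3 (0.70 log units; beyond the scatter). Each substitution on that ring raised the number, yet none of them introduces a methoxy or a 2-methoxyphenyl, so the present change is not covered directly. Among the compounds with values here, with no closer precedent, a step of modest size at most is expected in this assay, in either direction, and the estimate for compound 4 is therefore placed close to compound 2, at 15000 nM with a range from 5000 nM to 50000 nM, meaning an expected step of a 1.3-fold lower number from compound 2 to compound 4 (0.11 log units; within the scatter).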

Compound 4, concentration for 50% growth inhibition: 30500 nM
Estimate against measurement, compound 4: 2.0-fold (0.31 log units) below; low and high end bracket the measured number.
By their numbers in this assay, from the lowest: compound 1; then compounds 2 and 4 (each within the scatter of the next); then compound 3.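

In this assay, the 2-methoxyphenyl group reads the same as 4-methylphenyl on the carbon with a double bond to nitrogen (a 1.6-fold higher number from compound 2 to compound 4 (0.19 log units; within the scatter)), so this position also tolerates a substituted ring that carries a hydrogen-bond acceptor, and one substituted at a different ring carbon. Methoxy nevertheless joins methyl and trifluoromethyl in giving a higher number than the unsubstituted phenyl (a 4.6-fold higher number from compound 1 to compound 4 (0.66 log units; beyond the scatter)), while the 2-methoxyphenyl compound stays clearly apart from the 4-(trifluoromethyl)phenyl one (a 3.2-fold lower number from compound 3 to compound 4 (0.50 log units; beyond the scatter)). Nothing available here explains these differences.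

Because compound 4 changes both the group and its place on the ring, the compounds shown leave open how much of its value belongs to methoxy itself, which 4-methoxyphenyl would separate. They also leave open whether any group on this ring, such as an amine or a hydroxyl, would give a lower number than hydrogen.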